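A few compounds are considered here, and "the series" means these few. Any claim that something is new, unique, unknown or untested is made for them only; others in the source may bear on it.

Compound 1 `Fc1ccc(-c2cn3ccnc3c(-c3ccc4ncn(C5CCCCC5)c4c3)n2)cc1`: 33.4%
Compound 2 `CCc1ccc(-c2cn3ccnc3c(-c3ccc4ncn(Cc5ccccc5)c4c3)n2)cc1`: 49.7%

In a functional assay on CCRF-CEM cells (Homo sapiens) for inhibition, read by sulforhodamine B assay, with a stated time of 48 h, tested at 10 uM (on this read-out lower numbers stand for less inhibition and higher numbers for more inhibition at the one concentration tested (going by the name of the read-out)), compound 2 gives 49.7%, the highest of the two numbers; in this assay compound 1 gives 33.4%, a gap beyond the scatter. For the measured compounds named here, no pair of measured compounds differs in one place, so no measured step guides the move to compound 3 `O=Cc1ccc(-c2cn3ccnc3c(-c3ccc4ncn(Cc5ccccc5)c4c3)n2)cc1`, which differs from compound 2 by formyl in place of ethyl on an aromatic carbon. A small step downward, near the edge of the scatter, is expected as a number 9.7 percentage points lower from compound 2 to compound 3 (within the scatter). Compound 3 is therefore estimated at 40%, between 15% and 65%.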

Compound 3, a percentage reported as inhibition, at one concentration (the size of the read-out at that concentration, not a potency): 77.9%
The estimate for compound 3 lay 37.9 percentage points below the measured number, outside the stated range (above it).
By their numbers in this assay, from the lowest: compound 1; then compound 2; then compound 3.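

In this assay, for the compounds shown here, the 4-ethylphenyl to 4-formylphenyl change gives a number 28.2 percentage points higher from compound 2 to compound 3 (beyond the scatter), the first one-place step, and it shows that this position, para to a large group, responds to the group placed on it. Formyl brings a hydrogen-bond acceptor and a double bond that ethyl lacks, but nothing shown ties the rise to either feature. The compounds shown leave open how an amine, a carboxylic acid or a longer chain would read at this position, and whether the formyl gain would hold with the cyclohexyl group of compound 1 in place of benzyl.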